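The source may report more compounds than this note shows. Statements on the series, on what has been measured and on what is new or still open speak of the compounds shown alone.

Three compounds were measured in a toxicity assay on MT4 cells (Homo sapiens) for cytotoxicity, read by MTT assay; on this read-out higher numbers stand for lower toxicity in this test and lower numbers for higher toxicity in this test:

- compound 1 `Cc1cc(-c2ccc(C#N)cc2)cc(C)c1Oc1cc(N)nc(Nc2ccc(C#N)cc2)n1` gives 18100 nM
- compound 2 `Cc1cc(-c2ccccc2)ccc1Oc1cc(N)nc(Nc2ccc(C#N)cc2)n1` gives 20000 nM
- compound 3 `Cc1cc(-c2ccccc2C#N)ccc1Oc1cc(N)nc(Nc2ccc(C#N)cc2)n1` gives 28600 nM

These three values lie within the usual scatter of one another, so compound 3 sits in a single group with compound 1 and compound 2, and no order among them can be read from the numbers.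

The next compound to be tested is compound 4 `Cc1cc(-c2ccc(C#N)cc2)ccc1Oc1cc(N)nc(Nc2ccc(C#N)cc2)n1`, which has the same atoms as compound 3 joined differently: 4-cyanophenyl in place of 2-cyanophenyl on an aromatic carbon. In words, 4-cyanophenyl stands in place of 2-cyanophenyl on an aromatic carbon.

Going by the values given here, only one measured step changes a single place and touches this group, and that is a 1.4-fold higher number from compound 2 to compound 3 (0.16 log units; within the scatter). It is within the scatter, so adding the cyano group did not move the number measurably. Compound 1 also carries 4-cyanophenyl, though it differs from compound 4 in a further place, and compound 1 gives 18100 nM, in the same range. Among the compounds with values here, no measured step shows what moving the cyano group does by itself. Even so, no step beyond the scatter is expected in this assay.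

The expected step is a 1.3-fold lower number from compound 3 to compound 4 (0.11 log units; within the scatter).

Compound 4 is estimated at 22000 nM, with an expected range from 12000 nM to 40000 nM.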

Compound 4, half-maximal cytotoxic concentration: 10400 nM
Beside the measured number, compound 4's estimate is 2.1-fold (0.33 log units) above it, outside the stated range (below it).
By their numbers in this assay, from the lowest: compounds 4, 1, 2 and 3 (each within the scatter of the next, the first and the last beyond it).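

In this assay, the change from 2-cyanophenyl to 4-cyanophenyl gives a 2.8-fold lower number from compound 3 to compound 4 (0.44 log units; beyond the scatter), which lies beyond the scatter and, since a lower number stands for higher toxicity in this test, points toward more toxicity. This is the first sign in these compounds that the place of the cyano group on this ring can show in the number, whereas adding a cyano group in the 2-cyanophenyl form had shown no measurable change. The two other routes to compound 4 stay within the scatter, with the addition of the cyano group giving a 1.9-fold lower number from compound 2 to compound 4 (0.28 log units; within the scatter) and hydrogen in place of methyl giving a 1.7-fold lower number from compound 1 to compound 4 (0.24 log units; within the scatter), and no measurement here explains the difference between the two cyano placements.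

The compounds shown leave open whether this difference belongs to the nitrile itself, or whether a carboxylic acid or an amine in its place would separate the same two places on the ring. They also leave open whether the same step would appear on the core of compound 1, with its extra methyl group.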